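Opening the ring of compound 3

A few compounds are considered here, and "the series" means these few. Any claim that something is new, unique, unknown or untested is made for them only; others in the source may bear on it.

In a physicochemical assay for solubility, in phosphate buffer, at pH 7.4 (on this read-out lower numbers stand for lower solubility and higher numbers for higher solubility), compound 3 (`CNC(=O)Nc1cc(Oc2cncc(C)c2)c([C@H]2C[C@@H](O)C2)cn1`) gives 332000 nM. Compound 1 (`CCOCCc1cnc(NC(=O)NC)cc1Oc1cncc(C)c1`) gives 500000 nM, and compound 2 (`CNC(=O)Nc1cc(Oc2cncc(C)c2)c(CCCO)cn1`) gives 500000 nM, so the three numbers lie within the scatter of one another.

Compound 4 (`CNC(=O)Nc1cc(Oc2cncc(C)c2)c(CCCCO)cn1`) carries 4-hydroxybutyl in place of 3-hydroxycyclobutyl on an aromatic carbon. Among the compounds with values here, no measured compound carries this exact chain, so the expectation rests on neighbouring steps. The closest is the one that joins the open 3-hydroxypropyl chain to the ring, which shows a 1.5-fold lower number from compound 2 to compound 3 (0.18 log units; within the scatter). The step between the two open chains shows no change at the digits printed from compound 1 to compound 2 (within the scatter), and the step from the ethoxy chain to the ring shows a 1.5-fold lower number from compound 1 to compound 3 (0.18 log units; within the scatter). None of these leaves the scatter, so no step beyond the scatter is expected in this assay, although a small move towards the open-chain numbers is possible.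

The estimated step is a 1.4-fold higher number from compound 3 to compound 4 (0.15 log units; within the scatter). Compound 4 is expected to read 470000 nM, with an estimated range of 280000 nM to 650000 nM.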

Compound 4, solubility: 500000 nM
The estimate for compound 4 lay 1.1-fold (0.03 log units) below the measured number; the range from low to high includes it.
By their numbers in this assay, from the lowest: compounds 3, 1, 2 and 4 (each within the scatter of the next).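

In this assay, removing the four-membered ring at this position while keeping the count of heavy atoms gives a 1.5-fold higher number from compound 3 to compound 4 (0.18 log units; within the scatter), so opening the ring to 4-hydroxybutyl leaves the read-out within the scatter. Among the open chains, the change from 3-hydroxypropyl to 4-hydroxybutyl gives no change at the digits printed from compound 2 to compound 4 (within the scatter), and the change from 2-ethoxyethyl to 4-hydroxybutyl gives no change at the digits printed from compound 1 to compound 4 (within the scatter), so neither chain length nor the place of the oxygen in these chains separates the compounds. The data shown offer no explanation for why these groups read alike.

On these data alone, it remains open whether a terminal amine, a carboxylic acid or a chain longer than 4-hydroxybutyl would produce a step beyond the scatter at this position. The other stereoisomer of 3-hydroxycyclobutyl also remains unaddressed by the compounds shown.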